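Shifting a nitrile on the sulfonyl-bound ring

This account rests on a few compounds, and the source may have more. Where it says the series, first, only, none or still open, it means among the compounds named here.

Compound 1 `COc1ccc(S(=O)(=O)c2cnc3cc(F)ccc3c2N2CCC(C)CC2)cc1`: 90%
Compound 2 `Cc1ccc2ncc(S(=O)(=O)c3cccc(C#N)c3)c(N3CCC(C)CC3)c2c1`: 52%
Compound 3 `COc1ccc2ncc(S(=O)(=O)c3cccc(C#N)c3)c(N3CCC(C)CC3)c2c1`: 90%

In an assay on isolated protein for displacement of a labelled ligand from metabotropic glutamate receptor 5 (Homo sapiens), with a stated time of 60 min, tested at 1 uM (on this read-out lower numbers stand for less inhibition and higher numbers for more inhibition at the one concentration tested (going by the name of the read-out)), compound 2 stands lowest of the three numbers, with compound 1 and compound 3 both well above it. Within the data shown here, the one single-change step, a number 38 percentage points higher from compound 2 to compound 3 (beyond the scatter), comes from a methoxy in place of methyl on an aromatic carbon. Compound 4 `Cc1ccc2ncc(S(=O)(=O)c3ccc(C#N)cc3)c(N3CCC(C)CC3)c2c1` keeps the methyl of compound 2 and differs from it only here: 4-cyanophenyl in place of 3-cyanophenyl on a sulfonyl sulfur. Among the measured compounds shown here, no measured step touches the position of the nitrile, so the measured step gives no guidance on this change. With nothing to point either way, compound 4 is expected to show a step of a number 2 percentage points lower from compound 2 to compound 4 (within the scatter), none beyond the scatter. The estimate for compound 4 is 50%, ranging from 25% to 75%.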

Compound 4, a percentage reported as inhibition, at one concentration (the size of the read-out at that concentration, not a potency): 55%
Beside the measured number, compound 4's estimate is 5 percentage points below it; measured number inside the range.
By their numbers in this assay, from the lowest: compounds 2 and 4 (each within the scatter of the next); then compounds 1 and 3 (each within the scatter of the next).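

Moving the nitrile, with 4-cyanophenyl in place of 3-cyanophenyl on a sulfonyl sulfur, gives a number 3 percentage points higher from compound 2 to compound 4 (within the scatter) in this assay, so the two nitrile positions cannot be told apart on the methyl-bearing core. Among these compounds, the swap on the core, by contrast, gives a number 38 percentage points higher from compound 2 to compound 3 (beyond the scatter), the only single-place step here beyond the scatter. Nothing available explains this result. Still open, from the compounds shown here alone, is whether 4-cyanophenyl would read the same on the methoxy-bearing core of compound 3, and whether a carboxylic acid in place of the nitrile would keep the inhibition.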